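Swapping the Piperidine Cap on a Benzoxazole Series

This account rests on a few compounds, and the source may have more. Where it says the series, first, only, none or still open, it means among the compounds named here.

Measured so far:
- compound 2, `CN1CCC(Oc2ccc(-c3nc4ccc(Oc5ccc(Cl)cc5)cc4o3)cc2)CC1`: 19.5%
- compound 3, `CCN1CCC(COc2ccc(-c3nc4ccc(Oc5ccc(Cl)cc5)cc4o3)cc2)CC1`: 2.1%
- compound 1, `Clc1ccc(Oc2ccc3nc(-c4ccc(OCC5CCNCC5)cc4)oc3c2)cc1`: "not active" (no number reported)

These three compounds share one core and differ only in the group carried on an oxygen of the aromatic ring at one end. In an assay on isolated protein for inhibition of advanced glycosylation end product-specific receptor (Homo sapiens), read by FRET, with stated times of 30 min and 1 h, tested at 4 uM (a lower number here means less inhibition, a higher number more inhibition at the concentration tested (going by the name of the read-out)), compound 2 gives 19.5%, the highest of the two numbers reported, while compound 3 gives 2.1% and compound 1 is reported as "not active" (no number reported), without a number.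

Compound 4, `CC(C)N1CCC(COc2ccc(-c3nc4ccc(Oc5ccc(Cl)cc5)cc4o3)cc2)CC1`, has not yet been measured. It differs from compound 2 in one place: (1-isopropylpiperidin-4-yl)methyl in place of 1-methylpiperidin-4-yl on an oxygen on an aromatic ring.

Going by the values given here, the one measured step that bears on this change is the move from compound 2 to compound 3, a number 17.4 percentage points lower from compound 2 to compound 3 (beyond the scatter), where the same methylene link was inserted and a small alkyl group on the nitrogen was enlarged. Compound 4 carries both features as well, so a drop of similar size is expected, giving a number 15.5 percentage points lower from compound 2 to compound 4 (beyond the scatter). Compound 4 is therefore estimated at 4%, in the range 0% to 15%.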

Compound 4, a percentage reported as inhibition, at one concentration (the size of the read-out at that concentration, not a potency): 26.2%
Estimate against measurement, compound 4: 22.2 percentage points below, and the stated range ends below it.
By their numbers in this assay, from the lowest: compound 3; then compounds 2 and 4 (each within the scatter of the next).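

In this assay, (1-isopropylpiperidin-4-yl)methyl in place of 1-methylpiperidin-4-yl on this oxygen gives a number 6.7 percentage points higher from compound 2 to compound 4 (within the scatter), so the longer group with its extra carbon does not on its own bring the low reading of compound 3. The sharper contrast lies on the piperidine nitrogen, where methyl in place of hydrogen on the chain carbon bound to that nitrogen gives a number 24.1 percentage points higher from compound 3 to compound 4 (beyond the scatter), which shows that this position responds strongly to one small change. No measured evidence here explains that contrast.

The compounds shown leave open whether a tert-butyl or cyclopropyl group on the same nitrogen would read like compound 4 or like compound 3. They also leave open how a 1-isopropylpiperidin-4-yl group placed directly on the oxygen would read.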